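Moving the Chlorine on a Benzyl Ether

The source may hold more compounds than are shown below. What is called first, only, known or untested is meant among the compounds shown, and "the series" means these compounds.

Two compounds have so far been measured in an assay on mitochondria for inhibition of Amine oxidase [flavin-containing] A (Rattus norvegicus), tested at 100 uM; a higher number here means more inhibition at the concentration tested (going by the name of the read-out), a lower number less inhibition:
compound 1, `C[C@H](NCc1ccc(OCc2ccc([N+](=O)[O-])cc2)cc1)C(N)=O`, gives 22%
compound 2, `NC(=O)[C@@H](NCc1ccc(OCc2cccc(Cl)c2)cc1)c1ccccc1`, gives 33%

Among these two numbers compound 2 stands highest. Its nearest neighbour is compound 1, whose number lies lower by a gap beyond the usual scatter of repeated measurements. Going by the values given here, these two compounds differ in more than one place at once, so no single structural step can be read from the pair, and no step between compounds that differ in only one place is yet known.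

Compound 3, `NC(=O)[C@@H](NCc1ccc(OCc2ccc(Cl)cc2)cc1)c1ccccc1`, has not yet been measured. It keeps the whole of compound 2 except for one point: 4-chlorophenyl in place of 3-chlorophenyl on a saturated chain carbon bound to an oxygen on an aromatic ring. The two have the same atoms, joined differently.

Among the compounds with values here, with no measured single-point step to serve as a yardstick, a shift this small, with nothing else altered, is expected to produce a step of no change at the digits printed from compound 2 to compound 3 (within the scatter) that lies within the scatter rather than beyond it. Compound 3 is therefore estimated at 33%, within a range from 18% to 50%.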

Compound 3, a percentage reported as inhibition, at one concentration (the size of the read-out at that concentration, not a potency): 27%
For compound 3 the middle estimate is 6 percentage points above the measured one, and the stated range covers the measured number.
By their numbers in this assay, from the lowest: compounds 1, 3 and 2 (each within the scatter of the next, the first and the last beyond it).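

In this assay, the change of 4-chlorophenyl in place of 3-chlorophenyl on a saturated chain carbon bound to an oxygen on an aromatic ring gives a number 6 percentage points lower from compound 2 to compound 3 (within the scatter). Going by these compounds alone, this is the first comparison that isolates a single point, and it shows that this assay does not separate these two placements of the chlorine, at least in this one pair. No measurement shown explains why the two placements read so alike, and none says how the chlorine acts here.

The compounds shown leave open whether the chlorine matters at all, as neither a plain phenyl nor a group such as methoxy or trifluoromethyl in its place appears among them, so the size of a change at this ring remains unknown. Compound 1 differs from compound 2 and compound 3 in more than one place, so the separate contributions of its nitro-bearing ring and of the methyl on its chain, where they carry a phenyl, also remain unresolved.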